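The source may report more compounds than this note shows. Statements on the series, on what has been measured and on what is new or still open speak of the compounds shown alone.

Measured in a functional assay on MCF7 cells (Homo sapiens) for cytotoxicity, read by MTT assay, with a stated time of 72 h; on this read-out lower numbers stand for stronger inhibition of growth and higher numbers for weaker inhibition of growth:
compound 1 `C[Se]/C(=N\C(=O)c1ccco1)NC(=O)c1ccco1` gives 88900 nM
compound 2 `CS/C(=N\C(=O)c1csc([N+](=O)[O-])c1)NC(=O)c1csc([N+](=O)[O-])c1` gives 78100 nM
compound 3 `CS/C(=N\C(=O)c1cnc2ccccc2c1)NC(=O)c1cnc2ccccc2c1` reaches only a limit of the assay, > 100000 nM

Compound 2 holds one of the two numbers recorded in this assay; the value of compound 1 sits within the usual scatter of it, so the two cannot be placed in order. Compound 3 gives a limit and no number, as noted under (the limit of > 100000 nM in this assay, at which 1 of the 3 values shown sits).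

The step followed here runs from compound 2 to compound 4 `C[Se]/C(=N\C(=O)c1csc([N+](=O)[O-])c1)NC(=O)c1csc([N+](=O)[O-])c1`, which has not yet been measured in this assay. The change is a group of 2 heavy atoms (1 carbon, 1 selenium; no ring) in place of a group of 2 heavy atoms (1 carbon, 1 sulfur; no ring), on a carbon with a double bond to nitrogen. Among the compounds with values here, compound 1 already carries this selenium-bearing group on a different pair of acyl groups and lands in the same region as compound 2, but no measured pair differs in this exchange alone, so the direction of the step is not pinned down by the data. In this assay a step of no more than the scatter is expected from compound 2 to compound 4, with a slight lean toward stronger inhibition of growth.

Compound 4 is therefore estimated at 60000 nM, with a likely range from 25000 nM to 150000 nM, the expected step being a 1.3-fold lower number from compound 2 to compound 4 (0.11 log units; within the scatter).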

Compound 4, concentration for total growth inhibition: 28100 nM
Beside the measured number, compound 4's estimate is 2.1-fold (0.33 log units) above it; the measured number falls inside the stated range.
By their numbers in this assay, from the lowest: compound 4; then compounds 2 and 1 (each within the scatter of the next). At a limit, above all of these: compound 3.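

In this assay, within the data shown here, the exchange of methylsulfanyl for the selenium-bearing group of the same size gives a 2.8-fold lower number from compound 2 to compound 4 (0.44 log units; beyond the scatter), the only measured pair that isolates this change. The carbon with a double bond to nitrogen, whose other neighbours are the two amide-type nitrogens, is therefore a place where this single-atom exchange can move growth inhibition beyond the scatter, though the step is modest and the overall level remains weak. The finding holds for the acyl groups shared by compound 2 and compound 4 only; compound 1 carries the same selenium-bearing group on different acyl groups, so it neither supports nor tests the step.

Still open is whether the step carries over to other acyl groups, since compound 1 has no methylsulfanyl partner among the compounds shown, and whether a longer chain on selenium, such as ethyl, or an amine at the same carbon would hold, extend or lose it. Compound 3 gives a limit and not a number, so it offers no measured level for its acyl groups: the limit of > 100000 nM in this assay, at which 1 of the 4 values shown sits.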